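The compounds below may be only part of what the source reports. "The series", "measured", "known", "first", "only" and "open" are said of these compounds alone.

Measured in a functional assay on SGC-7901 cells (Homo sapiens) for antiproliferative activity, read by sulforhodamine B assay, with a stated time of 72 h; on this read-out lower numbers stand for stronger inhibition and higher numbers for weaker inhibition:

compound 1 `S=C(N/N=C/c1ccc2ccccc2n1)Nc1ccc(Br)cc1` — 69400 nM
compound 2 `CN(C)C(=S)N/N=C/c1nc2ccccc2s1` — 830 nM
compound 3 `NC(=S)N/N=C/c1cc2cccnc2s1` — 100000 nM

Of the three numbers, compound 1 gives the second highest. Compound 3 sits close to it, and the gap between compound 1 and compound 3 lies within the usual scatter, so the two cannot be told apart on this read-out. Compound 2, built on a different core and carrying a dimethylamino group on the thiocarbonyl carbon, gives a far lower number than compound 1, and that gap is well beyond the scatter. Among the measured compounds shown here, with three compounds on three cores and no pair differing in a single place, no measured step on the shared thiosemicarbazone motif is available.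

Compound 4 `S=C(NCc1ccccc1)N/N=C/c1ccc2ccccc2n1` keeps the core of compound 1 and differs only at the thiourea nitrogen: benzyl in place of 4-bromophenyl on an amide-type nitrogen. For the measured compounds named here, no measured pair isolates such an exchange, so the size and direction of its effect are unknown from these data. For compound 4 the step of a 1.5-fold lower number from compound 1 to compound 4 (0.19 log units; within the scatter) is expected to stay small, with a wide band allowed either way. The value expected for compound 4 in this assay is 45000 nM, between 8000 nM and 100000 nM.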

Compound 4, half-maximal inhibitory concentration: 53700 nM
Compound 4: middle estimate off by 1.2-fold (0.08 log units), on the low side; the range from low to high includes it.
By their numbers in this assay, from the lowest: compound 2; then compounds 4, 1 and 3 (each within the scatter of the next).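

In this assay, among the compounds shown here, benzyl in place of 4-bromophenyl on the amide-type nitrogen gives a 1.3-fold lower number from compound 1 to compound 4 (0.11 log units; within the scatter), the first single-place step in this set, and it leaves compound 1 and compound 4 indistinguishable on this read-out. On the core of compound 1, this position therefore accepts the loss of the bromine and the exchange of 4-bromophenyl for benzyl with no change that can be told from the usual scatter, though this rests on a single pair and on two groups that each carry one aromatic carbon ring. No measurement at hand gives a reason for this result, and none bears on how either group acts at this nitrogen.

Still open, going by these compounds, is whether this tolerance extends to groups of another kind on the same nitrogen, such as a longer chain like phenethyl, a plain methyl, or a benzyl carrying an amine or a carboxylic acid. Equally open, on these data alone, is what a dimethylamino group on the thiocarbonyl carbon would give on the core of compound 1, which would test directly whether that group can bring the number down on this core.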